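A few compounds are considered here, and "the series" means these few. Any claim that something is new, unique, unknown or untested is made for them only; others in the source may bear on it.

Measured in a physicochemical assay for acid dissociation:
compound 2 `COc1ccc(Oc2ccc3c(NCCCNCc4cc(F)ccc4OC)ccnc3c2)cc1` gives 9.28
compound 3 `COc1ccc(Oc2ccc3c(NCCCNCc4cccc(OC)c4O)ccnc3c2)cc1` gives 9.28
compound 1 `Fc1ccc(-c2ccc3c(NCCCNCc4ccco4)ccnc3c2)cc1` gives 9.47

Compound 2 is level with compound 3 at the digits shown, and together they are the lowest of the three; compound 1 differs from compound 2 only within the scatter.

Compound 4 `COc1ccc(F)cc1CNCCCNc1ccnc2cc(Oc3ccccc3)ccc12` has not yet been measured in this assay. It differs from compound 2 by hydrogen in place of methoxy on an aromatic carbon.

Among the measured compounds shown here, only one measured step exists to compare with: no change at the digits printed from compound 2 to compound 3 (within the scatter). That step changed the group on the saturated chain carbon bound to the amine nitrogen and moved nothing. The present change is a different one, 4-methoxyphenoxy to phenoxy, so no step beyond the scatter is expected. Compound 4 is therefore expected to give about 9.28, between 8.95 and 9.6, an expected step of no change at the digits printed from compound 2 to compound 4 (within the scatter).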

Compound 4, acid dissociation constant: 9.28
For compound 4 middle estimate and measured number coincide at the digits printed, and the stated range covers the measured number.
By their numbers in this assay, from the lowest: compounds 2, 3, 4 and 1 (each within the scatter of the next).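

Replacing methoxy with hydrogen, which turns 4-methoxyphenoxy into phenoxy, gives no change at the digits printed from compound 2 to compound 4 (within the scatter) in this assay, the first step shown at this position. The earlier step changed only the group on the saturated chain carbon, so this result adds that the methoxy on this aromatic carbon can also go without a step beyond the scatter. Nothing measured here bears on why the number holds.

Only methoxy and hydrogen are compared at this position. An amine, a carboxylic acid or a longer chain there remains an open case.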